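The source may report more compounds than this note shows. Statements on the series, on what has been measured and on what is new or still open speak of the compounds shown alone.

Measured so far:
- compound 1 `CC(C)N1CCN(Cc2csc(N)c2C(=O)c2ccc(Cl)cc2)CC1`: 0%
- compound 2 `Nc1scc(CN2CCN(c3ccc(Cl)cc3F)CC2)c1C(=O)c1ccc(Cl)cc1`: 1%

In an assay on CHO cells for displacement of a labelled ligand from adenosine receptor A3 (Homo sapiens), read by scintillation counting, with a stated time of 120 min, tested at 10 uM (on this read-out lower numbers stand for less inhibition and higher numbers for more inhibition at the one concentration tested (going by the name of the read-out)), compound 1 gives 0%, and in this assay compound 2 gives 1%. Of the two numbers shown, the entry for compound 2 is the top one, yet the step of a number 1 percentage points higher from compound 1 to compound 2 (within the scatter) lies within the scatter, so the two compounds are not told apart by this read-out; both sit at essentially no inhibition at the single concentration tested.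

Compound 3 `COc1ccc(N2CCN(Cc3csc(N)c3C(=O)c3ccc(Cl)cc3)CC2)cc1` is the next member of the series. Compared with compound 2 it carries 4-methoxyphenyl in place of 4-chloro-2-fluorophenyl on an amine nitrogen in a ring. Among the compounds with values here, the only measured step that bears on this change is a number 1 percentage points higher from compound 1 to compound 2 (within the scatter), in which the group on the same ring nitrogen was exchanged without any movement beyond the scatter. With the core, the ketone and the remaining substituents unchanged, no step beyond the scatter is expected for compound 3, namely a number 1 percentage points higher from compound 2 to compound 3 (within the scatter). The value of compound 3 is therefore estimated at 2%, with a range from -6% to 12%.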

Compound 3, a percentage reported as inhibition, at one concentration (the size of the read-out at that concentration, not a potency): 0%
Compound 3: the middle estimate sits 2 percentage points above what was measured, within the range that was stated.
By their numbers in this assay, from the lowest: compounds 1, 3 and 2 (each within the scatter of the next).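

In this assay, the 4-methoxyphenyl group on the amine nitrogen in the ring gives a number 1 percentage points lower from compound 2 to compound 3 (within the scatter), and against the isopropyl group it gives no change at the digits printed from compound 1 to compound 3 (within the scatter). Replacing the chlorine and fluorine on the aromatic ring with a methoxy group therefore does not separate these compounds, and isopropyl, 4-chloro-2-fluorophenyl and 4-methoxyphenyl remain indistinguishable at this position in this read-out. Nothing available explains this flat result.

Going by these compounds, all three compounds sit at essentially no inhibition at the single concentration tested, so it remains open whether any group on this nitrogen can raise the read-out. Also open, on these data alone, is whether a carboxylic acid or a longer chain ending in an amine at this position, or a change elsewhere on the shared core, would give measurable displacement.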